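Changing the aryl group on the carbonyl of compound 1

A few compounds are considered here, and "the series" means these few. Any claim that something is new, unique, unknown or untested is made for them only; others in the source may bear on it.

Compound 1 `Cc1cc(S(N)(=O)=O)ccc1NC(=O)COc1ccc(Cl)cc1NC(=O)c1cccc(F)c1` gives 243000 nM
Compound 2 `Cc1cc(S(N)(=O)=O)ccc1NC(=O)COc1ccc(Cl)cc1NC(=O)c1cccc([N+](=O)[O-])c1` gives 58800 nM
Compound 3 `COc1ccc(C(=O)Nc2cc(Cl)ccc2OCC(=O)Nc2ccc(S(N)(=O)=O)cc2C)cc1` gives 69500 nM

In a functional assay on C8166 cells (Homo sapiens) for cytotoxicity, read by MTT assay (a higher number here means that more compound is tolerated, a lower number that less compound is tolerated), compound 1 stands highest of the three at 243000 nM on the numbers shown. Compound 4 `Cc1ccc(C(=O)Nc2cc(Cl)ccc2OCC(=O)Nc2ccc(S(N)(=O)=O)cc2C)c(C)c1` has not yet been measured. It carries 2,4-dimethylphenyl in place of 3-fluorophenyl on a carbonyl carbon.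

The closest measured change is a 3.5-fold lower number from compound 1 to compound 3 (0.54 log units; beyond the scatter) with 4-methoxyphenyl in place of 3-fluorophenyl on a carbonyl carbon. A second measured change is a 4.1-fold lower number from compound 1 to compound 2 (0.62 log units; beyond the scatter) with nitro in place of fluoro on an aromatic carbon. Between those two products the step is a 1.2-fold higher number from compound 2 to compound 3 (0.07 log units; within the scatter) and they therefore read alike. Neither change involves 2,4-dimethylphenyl, so the comparison is only indirect.

Resting on a 3.5-fold lower number from compound 1 to compound 3 (0.54 log units; beyond the scatter) as the nearest precedent, a modest step toward a lower number is expected in this assay for the new group. The estimated change is a 2.9-fold lower number from compound 1 to compound 4 (0.46 log units; beyond the scatter) and it carries real uncertainty. For compound 4 the expected value is 85000 nM (estimated range 38000 nM to 230000 nM)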

Compound 4, half-maximal cytotoxic concentration: 47600 nM
For compound 4 the middle estimate is 1.8-fold (0.25 log units) above the measured one; the measured number falls inside the stated range.
By their numbers in this assay, from the lowest: compounds 4, 2 and 3 (each within the scatter of the next); then compound 1.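

Placing 2,4-dimethylphenyl on the carbonyl carbon gives a 5.1-fold lower number from compound 1 to compound 4 (0.71 log units; beyond the scatter) in this assay and so extends the lowering seen with the earlier replacements of 3-fluorophenyl to an aryl group bearing only carbon substituents. The new group reads alike with the other two replacements, with a 1.5-fold lower number from compound 3 to compound 4 (0.16 log units; within the scatter) and with a 1.2-fold lower number from compound 2 to compound 4 (0.09 log units; within the scatter) as well. Among these four compounds, then, only the 3-fluorophenyl of compound 1 stands apart, while the other three aryl groups cannot be told apart in this assay, and nothing available explains this difference.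

From the compounds shown here alone, whether the higher number of compound 1 depends on the fluoro itself or on where it sits on the ring remains open. Also open, going by these compounds, is how an unsubstituted phenyl, a 3-chlorophenyl or a ring bearing an amine or a carboxylic acid would read at this position.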